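The source may hold more compounds than are shown below. What is called first, only, known or untested is meant among the compounds shown, and "the series" means these compounds.

Three compounds share one core and differ only in their side groups. In an assay on isolated protein for displacement of a labelled ligand from 5-hydroxytryptamine receptor 6 (Homo sapiens) (on this read-out higher numbers stand for weaker inhibition and lower numbers for stronger inhibition), compound 1 `CC(=N)NCC1CCCc2cc(S(=O)(=O)c3ccccc3)ccc21` gives 0.631 nM, compound 2 `COc1cccc(S(=O)(=O)c2ccc3c(c2)CCC[C@H]3CN)c1` gives 0.398 nM, and compound 3 `O=S(=O)(c1cccc(F)c1)c1ccc2c(c1)CCC[C@H]2CNCCO` gives 0.126 nM, the lowest of the three numbers, with both gaps lying beyond the usual scatter, so compound 3 binds most strongly here. Compound 4 `CC(=O)N(C)C[C@@H]1CCCc2cc(S(=O)(=O)c3cccc(F)c3)ccc21` is not yet measured. Within the data shown here, it differs from compound 3 in one place: acetyl(methyl)amino in place of (2-hydroxyethyl)amino on a saturated chain carbon bound to a saturated ring carbon No measured pair shows this change, so the expectation rests on the change alone. A step toward a higher number, a 20-fold higher number from compound 3 to compound 4 (1.30 log units; beyond the scatter), is expected, meaning weaker binding, with wide uncertainty. Compound 4 is therefore estimated at 2.5 nM, between 0.3 nM and 25 nM.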

Compound 4, inhibition constant: 1.59 nM
Compound 4: the middle estimate sits 1.6-fold (0.20 log units) above what was measured, and the stated range covers the measured number.
By their numbers in this assay, from the lowest: compound 3; then compounds 2 and 1 (each within the scatter of the next); then compound 4.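

In this assay, among these compounds, the swap to acetyl(methyl)amino gives a 13-fold higher number from compound 3 to compound 4 (1.10 log units; beyond the scatter) and so shows that binding responds to the group at this place, which the earlier compounds, with no pair differing in one place, could not show. The entering group counts 0 hydrogen-bond donors against 2 in the leaving group, yet compound 4 still gives 1.59 nM in the low nanomolar range. No measurement at hand explains the step. From the compounds shown here alone, it remains open which part of the change carries the step: a methylamino or an acetylamino group at this place would help separate them.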